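This account rests on a few compounds, and the source may have more. Where it says the series, first, only, none or still open, it means among the compounds named here.

Measured compounds in a functional assay on A-431 cells (Homo sapiens) for antiproliferative activity, read by MTT assay, with a stated time of 72 h; a higher number here means a weaker inhibitor, a lower number a stronger inhibitor:
compound 1 `CN1CCN(Cc2ccc(NC(=O)Nc3ccc4ncnc(Nc5ccc(F)c(Cl)c5)c4c3)cc2)CC1` gives 4000 nM
compound 2 `O=C(Nc1ccc(CN2CCCCC2)cc1)Nc1ccc2ncnc(Nc3cccc(C(F)(F)F)c3)c2c1` gives 1550 nM
compound 3 `C[C@@H](Nc1ncnc2ccc(NC(=O)Nc3ccc(CN4CCN(C)CC4)cc3)cc12)c1ccccc1` gives > 10000 nM

The value of compound 3 is a limit of this assay, not a number; it is the case described by the limit of > 10000 nM in this assay, at which 1 of the 3 values shown sits. Among the two numbers shown, compound 2 has the lowest; compound 1 stands nearest, with a higher number beyond the scatter. Compound 1 and compound 2 differ in two places, so their values show only the combined effect.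

Among the measured compounds shown here, the one measured step, an at least 2.5-fold higher number from compound 1 to compound 3 (0.39 log units; beyond the scatter), concerns the substituent on the aniline nitrogen of the shared core and is at least modest in size.

Compound 4 `CN1CCN(c2ccc(NC(=O)Nc3ccc4ncnc(Nc5cccc(C(F)(F)F)c5)c4c3)cc2)CC1` is not yet measured. Its change from compound 2 is 4-methylpiperazin-1-yl in place of (piperidin-1-yl)methyl on an aromatic carbon. For the measured compounds named here, no measured step touches this position: the step from compound 1 to compound 3 alters a different part of the core, and the pair compound 1 / compound 2 changes two places at once. The expectation therefore rests on the size of the exchanged groups alone, with no direction indicated.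

Compound 4 is estimated at 2500 nM, with a range from 800 nM to 8000 nM; the expected step of a 1.6-fold higher number from compound 2 to compound 4 (0.21 log units; within the scatter) is no larger than modest in either direction.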

Compound 4, half-maximal inhibitory concentration: 2200 nM
Compound 4: the middle estimate sits 1.1-fold (0.06 log units) above what was measured; measured number inside the range.
By their numbers in this assay, from the lowest: compounds 2, 4 and 1 (each within the scatter of the next, the first and the last beyond it). At a limit, above all of these: compound 3.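

In this assay, among the compounds shown here, the exchange of (piperidin-1-yl)methyl for 4-methylpiperazin-1-yl on an aromatic carbon, para to a large group, gives the first reading at this position: a 1.4-fold higher number from compound 2 to compound 4 (0.15 log units; within the scatter). The two groups have the same count of heavy atoms, while the entering ring has 2 hetero atoms against 1 in the ring that leaves, and with the rest of the structure held constant, this exchange leaves the two values within the scatter of each other. Nothing in hand bears on the reason for this outcome.

The exchange alters both the ring and its link to the aromatic ring, so the contribution of each remains unresolved, and a direct comparison would need (4-methylpiperazin-1-yl)methyl on the trifluoromethyl-bearing structure of compound 2. Also open, going by these compounds, is whether the position stays this flat in the same assay with groups of another kind, such as morpholin-4-yl, a carboxylic acid or a longer chain ending in a primary amine.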